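A silicon group replaces 4-methylpiperazin-1-yl on compound 3

A few compounds are considered here, and "the series" means these few. Any claim that something is new, unique, unknown or untested is made for them only; others in the source may bear on it.

Three measured compounds share one core and differ only in the group on a saturated chain carbon bound to a double-bonded ring carbon. In a functional assay on A549 cells (Homo sapiens) for antiproliferative activity, read by MTT assay, with a stated time of 48 h (on this read-out higher numbers stand for weaker inhibition and lower numbers for stronger inhibition), compound 1 `COC/C1=C/C[C@](C)(CCC=C(C)C)/C=C/[C@@H](OC(=O)C=C(C)C)[C@](C)(O)/C=C/C1=O` gives 3950 nM while compound 2 `CC(C)=CCC[C@]1(C)/C=C/[C@@H](OC(=O)C=C(C)C)[C@](C)(O)/C=C/C(=O)/C(CCl)=C\C1` gives 150 nM and compound 3 `CC(C)=CCC[C@]1(C)/C=C/[C@@H](OC(=O)C=C(C)C)[C@](C)(O)/C=C/C(=O)/C(CN2CCN(C)CC2)=C\C1` gives 940 nM as the middle of the three numbers. Compound 4 `CC(C)=CCC[C@]1(C)/C=C/[C@@H](OC(=O)C=C(C)C)[C@](C)(O)/C=C/C(=O)/C(C[Si](C)(C)C(C)(C)C)=C\C1` carries one change against compound 3, namely a group of 7 heavy atoms (6 carbon, 1 silicon; no ring) in place of a group of 7 heavy atoms (5 carbon, 2 nitrogen; one six-membered non-aromatic ring with 2 hetero atoms), on a saturated chain carbon bound to a double-bonded ring carbon and nothing else. Among the measured compounds shown here, three measured steps bear on this place: a 26-fold lower number from compound 1 to compound 2 (1.42 log units; beyond the scatter) is large, and both a 4.2-fold lower number from compound 1 to compound 3 (0.62 log units; beyond the scatter) and a 6.3-fold higher number from compound 2 to compound 3 (0.80 log units; beyond the scatter) are modest in size. Swaps here therefore move the number both up and down, yet none of the measured compounds carries a group with silicon, so these steps give no direction for the new group. The expected change is none beyond the scatter, an estimated 1.1-fold higher number from compound 3 to compound 4 (0.03 log units; within the scatter) with room either way. For compound 4 the estimated value is 1000 nM (expected range 250 nM to 4000 nM).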

Compound 4, half-maximal inhibitory concentration: 4200 nM
Estimate against measurement, compound 4: 4.2-fold (0.62 log units) below, outside the stated range (above it).
By their numbers in this assay, from the lowest: compound 2; then compound 3; then compounds 1 and 4 (each within the scatter of the next).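

In this assay, among the compounds shown here, putting the silicon group in place of 4-methylpiperazin-1-yl gives a 4.5-fold higher number from compound 3 to compound 4 (0.65 log units; beyond the scatter), and in place of the chlorine atom it gives a 28-fold higher number from compound 2 to compound 4 (1.45 log units; beyond the scatter), so this silicon group is the first one at this chain carbon to be measured, and it matches neither of those two groups. Putting it in place of methoxy gives a 1.1-fold higher number from compound 1 to compound 4 (0.03 log units; within the scatter), which lies within the scatter, so the heavy-atom count of the group does not set the number here: equal counts differ beyond the scatter, while unequal counts do not. Nothing measured here explains these differences.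

It remains open whether the silicon atom itself matters, since a tert-butyl-bearing group with carbon in place of silicon is not among the compounds shown. A smaller silicon group such as trimethylsilyl, or an open-chain amine such as dimethylamino, would also help separate these effects.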